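Removing a nitro group in a benzothiophene amide solubility series

The compounds below may be only part of what the source reports. "The series", "measured", "known", "first", "only" and "open" are said of these compounds alone.

Measured so far in a physicochemical assay for solubility; on this read-out lower numbers stand for lower solubility and higher numbers for higher solubility:
compound 1 `COC(=O)c1ccc(NC(=O)c2cc3ccccc3s2)cc1` gives 20 ug/mL
compound 2 `COC(=O)c1ccc(NC(=O)c2cc3cc([N+](=O)[O-])ccc3s2)cc1` gives 10 ug/mL
compound 3 `NC(=O)c1ccccc1NC(=O)c1cc2cc([N+](=O)[O-])ccc2s1` gives 10 ug/mL

Compound 2 and compound 3 carry the same nitro group but differ elsewhere; the difference between the two cores is not broken down here. Compound 4 `NC(=O)c1ccccc1NC(=O)c1cc2ccccc2s1` has not yet been measured in this assay. From compound 2 to compound 1 the change is hydrogen in place of nitro on an aromatic carbon, and it gave a 2.0-fold higher number from compound 2 to compound 1 (0.30 log units; within the scatter). From compound 3 to compound 4 the change is hydrogen in place of nitro on an aromatic carbon, which is the same change at the same kind of place. For the measured compounds named here, the only guide is the earlier step, so an estimate for compound 4 of roughly a 2.0-fold higher number from compound 3 to compound 4 (0.30 log units; within the scatter) is expected, resting on compound 3 at 10 ug/mL and on the earlier step of a 2.0-fold higher number from compound 2 to compound 1 (0.30 log units; within the scatter). Compound 4 is therefore expected to give about 20 ug/mL, with a plausible range of 8 ug/mL to 50 ug/mL.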

Compound 4, solubility: < 5 ug/mL
Compound 4: only a limit was reported; the forecaster's own chance of this, stated with the estimate: 5%; middle value at least 4.0-fold (0.60 log units) from the limit.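

Carried to the core of compound 3, hydrogen in place of nitro on an aromatic carbon gave an at least 2.0-fold lower number from compound 3 to compound 4 (0.30 log units; that floor lies within the scatter) where the same change on the other core had given a 2.0-fold higher number from compound 2 to compound 1 (0.30 log units; within the scatter) so the printed numbers of the two steps do not run the same way. For the compounds shown here, the earlier step and the floor of the new one both lie within the scatter, so this shows only that the earlier step cannot be assumed to carry over, not that the change differs between the two cores. In this assay compound 4 gives only a limit and not a number (< 5 ug/mL) and the full size of its step stays unknown: the limit of < 5 ug/mL in this assay, at which 1 of the 4 values shown sits.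

The compounds shown leave open what a group other than nitro or hydrogen at this place, such as an amine or a carboxylic acid, would do on either core. They also leave open how far the two cores differ from each other without the nitro group.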